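Compound 4: Swapping Fluoro for 1-Hydroxy-1-methylethyl

The source may hold more compounds than are shown below. What is called first, only, known or untested is meant among the compounds shown, and "the series" means these compounds.

Compound 1 (`Fc1ccccc1-c1ccc2[nH]c(C3=NOC4(CCCCC4)C3)nc2c1`) is the reference point of this short series. Within the data shown here, in an ADME assay on microsomes from liver (Canis lupus familiaris) for metabolic stability, with a stated time of 10 min (on this read-out higher numbers stand for a more stable compound and lower numbers for a less stable compound), compound 1 gives 47%, the lowest of the three numbers measured so far. Compound 2 (`Fc1cccc(C(F)(F)F)c1-c1ccc2[nH]c(C3=NOC4(CCCCC4)C3)nc2c1`) gives 65%. Compound 3 (`Fc1ccccc1-c1cc(C(F)(F)F)c2[nH]c(C3=NOC4(CCCCC4)C3)nc2c1`) gives 82%. Each of these two carries trifluoromethyl in place of hydrogen on an aromatic carbon. The result is a modest step, a number 18 percentage points higher from compound 1 to compound 2 (beyond the scatter), and a large one, a number 35 percentage points higher from compound 1 to compound 3 (beyond the scatter).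

Compound 4 (`CC(C)(O)c1ccccc1-c1ccc2[nH]c(C3=NOC4(CCCCC4)C3)nc2c1`) has not yet been measured in this assay. Its change is of a different kind: 1-hydroxy-1-methylethyl in place of fluoro on an aromatic carbon. The new group sits on an aromatic carbon, ortho to a large group, where compound 1 has its fluoro. Neither measured step replaces fluoro or introduces 1-hydroxy-1-methylethyl, so both bear on this change only loosely. They show that single substitutions in this series can move the read-out by as much as a number 35 percentage points higher from compound 1 to compound 3 (beyond the scatter), but they say nothing firm about direction here. A small rise is therefore expected, most likely not beyond the scatter, and the uncertainty is wide. This estimate amounts to an expected a number 5 percentage points higher from compound 1 to compound 4 (within the scatter). For compound 4 the estimated value is 52%, with an expected range from 30% to 75%.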

Compound 4, percent of the compound remaining: 4.4%
Estimate against measurement, compound 4: 47.6 percentage points above; measured number below the stated range.
By their numbers in this assay, from the lowest: compound 4; then compound 1; then compound 2; then compound 3.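

In this assay, 1-hydroxy-1-methylethyl in place of fluoro on an aromatic carbon, ortho to a large group, gives a number 42.6 percentage points lower from compound 1 to compound 4 (beyond the scatter), so a single change at this position can move the read-out sharply downward. The two earlier steps, a number 18 percentage points higher from compound 1 to compound 2 (beyond the scatter) and a number 35 percentage points higher from compound 1 to compound 3 (beyond the scatter), both ran upward, and compound 4 is the one compound shown that goes against that direction, which means that a substitution on compound 1 does not by itself raise the number. Nothing shown here bears on the reason for this fall.

The compounds shown leave open which part of 1-hydroxy-1-methylethyl goes with the low number, since a tert-butyl or a methoxy on the same aromatic carbon would separate the hydroxyl from the branched carbon framework. Going by these compounds, it also remains open whether 1-hydroxy-1-methylethyl would give a comparably low number on a core that carries the trifluoromethyl of compound 3.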